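A few compounds are considered here, and "the series" means these few. Any claim that something is new, unique, unknown or untested is made for them only; others in the source may bear on it.

Measured compounds and values in a functional assay on CHO cells for agonist activity at adenosine receptor A2b (Homo sapiens), read by AlphaScreen and cAMP accumulation; on this read-out lower numbers stand for an effect already at smaller amounts and higher numbers for an effect only at larger amounts of compound:
compound 1 `CCOc1ccc(-c2c(C#N)c(N)nc(SCc3ccn[nH]3)c2C#N)cc1` gives 332 nM
compound 2 `N#Cc1c(N)nc(SCc2ccn[nH]2)c(C#N)c1-c1ccc(OCC2CC2)cc1` gives 84 nM

Compound 2 holds the lower of the two numbers in this assay. Among the compounds with values here, the only measured step, a 4.0-fold lower number from compound 1 to compound 2 (0.60 log units; beyond the scatter), separates it from compound 1 and concerns the chain on the oxygen of the aromatic ring, not the group on the sulfur side of the shared core.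

Compound 3 `N#Cc1c(N)nc(SCc2cccc(C(N)=O)c2)c(C#N)c1-c1ccc(OCC2CC2)cc1` differs from compound 2 in one place: 3-carbamoylphenyl in place of 1H-pyrazol-5-yl on a saturated chain carbon bound to a sulfur. Within the data shown here, no measured pair touches the group on the saturated chain carbon bound to the sulfur, so the step from compound 1 to compound 2 gives no guide to the direction or size of this change, and the two compounds measured so far cannot say whether a carbamoylbenzyl group is tolerated in this assay as well as the pyrazolylmethyl group.

With nothing to lean on but the value of compound 2, the expected step for compound 3 is a 1.3-fold higher number from compound 2 to compound 3 (0.12 log units; within the scatter), set near no change with wide bounds to both sides. Compound 3 is estimated at 110 nM in this assay, with a range from 25 nM to 500 nM.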

Compound 3, half-maximal effective concentration: 12.7 nM
Estimate against measurement, compound 3: 8.7-fold (0.94 log units) above; the whole stated range lies above it.
By their numbers in this assay, from the lowest: compound 3; then compound 2; then compound 1.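

In this assay, the group on the saturated chain carbon bound to a sulfur proves to be a position where a change moves the read-out, a point the earlier pair could not address: 3-carbamoylphenyl in place of 1H-pyrazol-5-yl gives a 6.6-fold lower number from compound 2 to compound 3 (0.82 log units; beyond the scatter). The five-membered aromatic ring with 2 hetero atoms can therefore be replaced by a six-membered aromatic ring of carbon only, bearing a carbamoyl group, without loss of agonist effect at smaller amounts of compound, even though the entering group has more heavy atoms and the same printed counts of hydrogen-bond donors and acceptors. Nothing available accounts for the direction or size of this step.

The single step changes the ring and adds the carbamoyl group together, so the compounds shown do not separate their contributions; an unsubstituted benzyl group, or a carboxylic acid or an amine in place of the carbamoyl group, would bear on that question. They also leave open whether the cyclopropyl in place of methyl change on the oxygen-bound chain would act in the same direction alongside the 3-carbamoylbenzyl group.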